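The source may report more compounds than this note shows. Statements on the series, on what has been measured and on what is new or still open speak of the compounds shown alone.

Of the compounds shown here, three that share one core have been measured so far. Compound 1 `CS(=O)(=O)c1ccc(C(=O)N2CCC(C(=O)N3CCc4ccccc43)CC2)cc1[N+](=O)[O-]` in an assay on isolated protein for inhibition of vitamin D3 receptor (Homo sapiens), read by fluorescence polarization (a lower number here means a stronger inhibitor, a higher number a weaker inhibitor), gives > 60000 nM, which is a limit of the assay rather than a number. Compound 2 `CN(Cc1ccccc1F)C(=O)C1CCN(C(=O)c2ccc(S(C)(=O)=O)c([N+](=O)[O-])c2)CC1` in this assay gives > 60000 nM, likewise only a limit. Compound 3 `CC1Cc2ccccc2N1C(=O)C1CCN(C(=O)c2ccc(S(C)(=O)=O)c([N+](=O)[O-])c2)CC1` in this assay gives > 60000 nM, again a limit. The steps a step that the two limits leave unreadable from compound 1 to compound 2, a step that the two limits leave unreadable from compound 1 to compound 3 and a step that the two limits leave unreadable from compound 2 to compound 3 cannot be read in size, since (the limit of > 60000 nM in this assay, at which 3 of the 3 values shown sit). Compound 4 `CS(=O)(=O)c1ccc(C(=O)N2CCC(C(=O)N3CCc4ccccc4C3)CC2)cc1[N+](=O)[O-]` differs from compound 3 in one place: 1,2,3,4-tetrahydroisoquinolin-2-yl in place of 2-methyl-2,3-dihydro-1H-indol-1-yl on a carbonyl carbon. For the measured compounds named here, no measured step covers this change, and every measured value is a limit, so only a weak expectation follows. Compound 4 is expected at 60000 nM, between 15000 nM and 200000 nM, most probably reported again only as a limit. The step of a number no higher from compound 3 to compound 4 (the limit leaves the size open) that this estimate means is expected to be small.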

Compound 4, half-maximal inhibitory concentration: > 60000 nM
Compound 4: only a limit was reported (the forecaster's own chance of this, stated with the estimate: 85%); the middle value sits exactly at the limit.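

For the compounds shown here, no step from compound 1, compound 2 or compound 3 to compound 4 can be read in size, since all four compounds give only a limit: the limit of > 60000 nM in this assay, at which 4 of the 4 values shown sit. What remains open is whether changing the group on the carbonyl carbon alters the true strength of any of these compounds in this assay.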